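The source may report more compounds than this note shows. Statements on the series, on what has been measured and on what is new or still open speak of the compounds shown alone.

Compound 1 `CCNC(=O)N1CCN(C(=S)SCc2cn(Cc3ccccc3F)nn2)CC1` gives 23700 nM in a functional assay on EC9706 cells (Homo sapiens) for cytotoxicity, read by MTT assay, with a stated time of 72 h (on this read-out higher numbers stand for weaker inhibition and lower numbers for stronger inhibition), and compound 2 `CCNC(=O)N1CCN(C(=S)SCc2cn(Cc3ccc(F)cc3)nn2)CC1` gives 27800 nM in this assay. Compound 3 `CCNC(=O)N1CCN(C(=S)SCc2cn(Cc3ccc(C)cc3)nn2)CC1` reaches only > 128000 nM in this assay, which is a limit of the assay and not a number. The steps of an at least 5.4-fold higher number from compound 1 to compound 3 (0.73 log units; beyond the scatter) and an at least 4.6-fold higher number from compound 2 to compound 3 (0.66 log units; beyond the scatter) show compound 3 sitting at the limit of > 128000 nM in this assay, at which 1 of the 3 values shown sits. Compound 4 `CCNC(=O)N1CCN(C(=S)SCc2cn(Cc3ccc(OC)cc3)nn2)CC1` carries the change (methoxy in place of methyl on an aromatic carbon). Within the data shown here, no measured pair swaps methyl for methoxy, so the nearest guide is the weak standing of compound 3 itself. The expected step of an at least 1.1-fold lower number from compound 3 to compound 4 (0.06 log units; that floor lies within the scatter) is small, within the scatter, with a real chance that compound 4 again only reaches a limit. Compound 4 is therefore estimated at 110000 nM, ranging from 30000 nM to 300000 nM.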

Compound 4, half-maximal inhibitory concentration: > 128000 nM
Compound 4 gave a limit, no number; the forecaster's own chance of this, stated with the estimate: 55%; at least 1.1-fold (0.06 log units) between middle value and limit.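

In this assay compound 4 gives only a limit, not a number, as compound 3 does, so the step between them cannot be read: the limit of > 128000 nM in this assay, at which 2 of the 4 values shown sit. Replacing fluoro with methoxy is a clear loss, shown by an at least 4.6-fold higher number from compound 2 to compound 4 (0.66 log units; beyond the scatter) and by an at least 5.4-fold higher number from compound 1 to compound 4 (0.73 log units; beyond the scatter). Thus 4-methoxyphenyl, like 4-methylphenyl, sits at the limit, while 4-fluorophenyl keeps a measurable value.

Going by these compounds, whether methoxy and methyl truly differ remains unknown. So does whether chloro or an amine at this place would keep a measurable value.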